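The source may hold more compounds than are shown below. What is called first, only, known or untested is meant among the compounds shown, and "the series" means these compounds.

Measured compounds:
compound 1 `COc1cc(-c2ccc(C)n2-c2ccc(-c3nc4ccc(F)cc4s3)cc2)cc(OC)c1OC` — 15400 nM
compound 2 `COc1ccc2nc(-c3ccc(-n4c(C)ccc4-c4ccc(F)cc4)cc3)sc2c1` — 13800 nM
compound 3 `COc1ccc(-c2ccc(C)n2-c2ccc(-c3nc4ccc(OC)cc4s3)cc2)cc1` — 12700 nM

All three were run in a functional assay on MDA-MB-231 cells (Homo sapiens) for cytotoxicity, read by MTT assay, with a stated time of 72 h; a higher number here means a weaker inhibitor, a lower number a stronger inhibitor. Compound 1 gives the highest of the three numbers, yet its gap to compound 2 and to compound 3 is within the scatter, so the three are treated as alike. The difference between the core of compound 1 and the core of compound 2 is not broken down here.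

Compound 4 `COc1ccc2nc(-c3ccc(-n4c(C)ccc4-c4cc(OC)c(OC)c(OC)c4)cc3)sc2c1` is not yet measured. It arises from compound 1 by methoxy in place of fluoro on an aromatic carbon. The same kind of change was made once before, from compound 2 to compound 3: methoxy in place of fluoro on an aromatic carbon. There the place is a six-membered aromatic ring of carbon only, para to a large group; in compound 4 the ring is part of a fused system of two rings, meta and para to a fused ring. That earlier step gave a 1.1-fold lower number from compound 2 to compound 3 (0.04 log units; within the scatter). On that basis the expected step from compound 1 to compound 4 is a 1.1-fold lower number from compound 1 to compound 4 (0.04 log units; within the scatter), resting on compound 1 at 15400 nM and on the step that produced compound 3.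

Compound 4 is expected at 14000 nM, estimated between 7000 nM and 28000 nM.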

Compound 4, half-maximal inhibitory concentration: 12900 nM
Estimate against measurement, compound 4: 1.1-fold (0.04 log units) above, within the range that was stated.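

In this assay, the change from 6-fluoro-1,3-benzothiazol-2-yl to 6-methoxy-1,3-benzothiazol-2-yl gives a 1.2-fold lower number from compound 1 to compound 4 (0.08 log units; within the scatter). Set beside the earlier case of methoxy in place of fluoro, the change carries from one core to the other with no difference that can be told apart: the same change on two cores in this assay, a 1.1-fold lower number (0.04 log units; within the scatter) from compound 2 to compound 3 and a 1.2-fold lower number (0.08 log units; within the scatter) from compound 1 to compound 4, 1.1-fold (0.04 log units) apart, within the scatter of two such steps. Within the data shown here, this shows a step within the scatter on both cores, but with only two pairs, neither step beyond the scatter, it does not show how the change would behave on any other core.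

The compounds shown leave open whether a different group at this place, such as an amine or a carboxylic acid, would give a step beyond the scatter. The same question stands for a longer chain, such as ethoxy or propoxy, in place of methoxy.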